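A few compounds are considered here, and "the series" means these few. Any claim that something is new, unique, unknown or untested is made for them only; others in the source may bear on it.

Measured in a functional assay on PC-3 cells (Homo sapiens) for cytotoxicity, read by MTT assay, with a stated time of 24 h; on this read-out lower numbers stand for stronger inhibition and higher numbers for weaker inhibition:
- Compound 1 `CCOC1C=C(CC[C@]2(C)[C@@H](C)CC[C@@]3(C)C(C(=O)O)=CC=C[C@@H]23)C(=O)O1`: > 40000 nM
- Compound 2 `C=C1CC[C@H](C)[C@@](C)(CCC2=CC(OCC)OC2=O)C/C=C\C=C/1C(=O)O`: > 40000 nM
- Compound 3 `C[C@H]1CC[C@@]2(C)C(C(=O)O)=CCC[C@H]2[C@]1(C)CCC1=CCOC1=O`: > 40000 nM

These three entries are limits of the assay, not numbers. The whole set shares one feature: the limit of > 40000 nM in this assay, at which 3 of the 3 values shown sit. Compound 2 therefore has only a limit, > 40000 nM, and no exact potency.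

Compound 4 `C=C1CC[C@H](C)[C@@](C)(CCC2=CC(OC)OC2=O)C/C=C\C=C/1C(=O)O` differs from compound 2 by one small change: hydrogen in place of methyl on a saturated chain carbon bound to an oxygen on a saturated carbon. This places hydrogen in place of methyl on a saturated chain carbon bound to an oxygen on a saturated carbon, turning ethoxy into methoxy. For the measured compounds named here, no measured pair shows what such a change does, so no step beyond the scatter is expected in this assay. This means an expected step that the limit leaves unreadable from compound 2 to compound 4. For compound 4 the estimated value is 50000 nM, with an expected range of 30000 nM to 100000 nM.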

Compound 4, half-maximal inhibitory concentration: > 40000 nM
Compound 4 gave a limit, no number (the forecaster's own chance of this, stated with the estimate: 90%); the middle value lies beyond the limit too.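

No step can be read from compound 2 to compound 4, since both values are limits and not numbers: the limit of > 40000 nM in this assay, at which 4 of the 4 values shown sit.

The compounds shown leave open whether any structural change would give a measurable potency.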